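Swapping the aryl group on the ring nitrogen

A few compounds are considered here, and "the series" means these few. Any claim that something is new, unique, unknown or untested is made for them only; others in the source may bear on it.

Compound 1 `Nc1nc(N)c2cc(CSC(=S)N3CCN(c4ccc(F)cc4)CC3)ccc2n1`: 2040 nM
Compound 2 `Nc1nc(N)c2cc(CSC(=S)N3CCN(c4ccc(F)cc4F)CC3)ccc2n1`: 5120 nM
Compound 3 `CC(=O)c1ccc(N2CCN(C(=S)SCc3ccc4nc(N)nc(N)c4c3)CC2)cc1`: not yet measured

In a functional assay on A549 cells (Homo sapiens) for antiproliferative activity, read by MTT assay, with a stated time of 72 h (a lower number here means a stronger inhibitor, a higher number a weaker inhibitor), compound 2 has the higher of the two numbers, 5120 nM. Compound 3 carries 4-acetylphenyl in place of 2,4-difluorophenyl on an amine nitrogen in a ring. Among the measured compounds shown here, the only measured step on this aryl group, a 2.5-fold higher number from compound 1 to compound 2 (0.40 log units; beyond the scatter), was modest and added a fluoro in place of hydrogen on an aromatic carbon. For the measured compounds named here, no acetyl compound has been measured, so only a small shift toward a lower number is expected, not clearly beyond the scatter. The estimated step is a 1.7-fold lower number from compound 2 to compound 3 (0.23 log units; within the scatter). For compound 3 the estimate is 3000 nM, with an expected range of 1000 nM to 9000 nM.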

Compound 3, half-maximal inhibitory concentration: 2550 nM
Compound 3: middle estimate off by 1.2-fold (0.07 log units), on the high side, and the stated range covers the measured number.
By their numbers in this assay, from the lowest: compounds 1, 3 and 2 (each within the scatter of the next, the first and the last beyond it).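

In this assay, the exchange of aryl groups on the ring nitrogen gives a 2.0-fold lower number from compound 2 to compound 3 (0.30 log units; within the scatter) and a 1.3-fold higher number from compound 1 to compound 3 (0.10 log units; within the scatter), both small enough to stay within the scatter. Unlike the added fluoro, which produced the only step beyond the scatter, acetyl in place of fluoro leaves the number within the scatter of compound 1. Nothing available explains this result.

Still open, as far as these compounds go, is whether an amine or a carboxylic acid in place of the acetyl would also stay within the scatter of compound 1.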